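A few compounds are considered here, and "the series" means these few. Any claim that something is new, unique, unknown or untested is made for them only; others in the source may bear on it.

Among the measured compounds shown here, compound 2 `CC(=O)Oc1ccccc1C(=O)O[C@H]1CO[C@H]2[C@@H]1OC[C@H]2OC(=O)c1ccc(C)cc1` shows the higher of the two numbers measured so far: in an ADME assay on a cell-free system (plasma, Homo sapiens) for metabolic stability, with Plasma (Rattus norvegicus) as the target, read by HPLC, at pH 7.4 (a lower number here means that the compound disappears faster, a higher number that the compound lasts longer), compound 2 gives 0.105 h, while compound 1 `CC(=O)Oc1ccccc1C(=O)O[C@H]1CO[C@H]2[C@@H]1OC[C@H]2OC(=O)c1ccnn1C` gives 0.0963 h. For the measured compounds named here, the only measured step, a 1.1-fold higher number from compound 1 to compound 2 (0.04 log units; within the scatter), swaps one aromatic group for another on a carbonyl carbon. Compound 3 `CC(=O)Oc1ccccc1C(=O)O[C@H]1CO[C@H]2[C@@H]1OC[C@H]2O[N+](=O)[O-]` differs from compound 2 by nitro in place of (4-methylphenyl)carbonyl on an oxygen on a saturated carbon. Going by the values given here, no measured step covers a change of this kind, so the closest guide is that both measured values lie near each other. A half-life for compound 3 near 0.1 h is therefore expected, within 0.05 h to 0.25 h. That estimate means a step of a 1.1-fold lower number from compound 2 to compound 3 (0.02 log units; within the scatter), expected to stay within the scatter.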

Compound 3, half-life: 0.0144 h
For compound 3 the middle estimate is 6.9-fold (0.84 log units) above the measured one, and the stated range ends above it.
By their numbers in this assay, from the lowest: compound 3; then compounds 1 and 2 (each within the scatter of the next).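

At this oxygen on a saturated carbon, exchanging one aromatic carbonyl group for another had left the numbers within the scatter of each other, but nitro changes the picture in this assay. Nitro in place of (4-methylphenyl)carbonyl gives a 7.3-fold lower number from compound 2 to compound 3 (0.86 log units; beyond the scatter), and nitro in place of (1-methyl-1H-pyrazol-5-yl)carbonyl gives a 6.7-fold lower number from compound 1 to compound 3 (0.83 log units; beyond the scatter), so this position does respond to the group it carries. Nothing measured here gives a reason for this drop. Still open, going by these compounds, is whether an acetyl group or a free hydroxyl on this oxygen would give a number close to that of compound 3 or close to those of the two aromatic carbonyl compounds.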